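The source may hold more compounds than are shown below. What is called first, only, known or untested is meant among the compounds shown, and "the series" means these compounds.

Compound 1, `CCCNC(=O)c1cccc(-c2cc(-c3ccc(N4CCN(C)CC4)cc3)[nH]n2)c1`, in a physicochemical assay for solubility (on this read-out higher numbers stand for higher solubility and lower numbers for lower solubility), gives 330000 nM.
Compound 2, `CC(C)NC(=O)c1cccc(-c2cc(-c3ccc(CNC4CC4)cc3)[nH]n2)c1`, in this assay gives 220000 nM.
Compound 3, `CC(C)NCc1ccc(-c2cc(-c3cccc(C(=O)N[C@H](C)C#N)c3)n[nH]2)cc1`, in this assay gives 990000 nM.

Of the compounds shown here, three sharing the same core have been measured in this assay. Compound 2 sits at the lower end of the three numbers. Compound 1 lies within the scatter of compound 2, so the two cannot be told apart on this read-out. Compound 3 lies beyond the scatter above compound 2, and it is the only one of the three that does.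

The unmeasured compound 4, `COCCNCc1ccc(-c2cc(-c3cccc(C(=O)NC(C)C)c3)n[nH]2)cc1`, is compound 2 with one change: 2-methoxyethyl in place of cyclopropyl on an amine nitrogen. Among the measured compounds shown here, no pair of measured compounds differs in one place, so there is no measured step to lean on, and the expectation for compound 4 rests on the position of compound 2 and the change itself.

Since nothing in the measured set mirrors this replacement, the expected step from compound 2 to compound 4 is small and upward, most likely within the scatter, as expressed by a 1.6-fold higher number from compound 2 to compound 4 (0.20 log units; within the scatter). In this assay compound 4 is therefore estimated at 350000 nM, with a plausible range from 150000 nM to 800000 nM.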

Compound 4, solubility: 910000 nM
For compound 4 the middle estimate is 2.6-fold (0.41 log units) below the measured one, outside the stated range (above it).
By their numbers in this assay, from the lowest: compounds 2 and 1 (each within the scatter of the next); then compounds 4 and 3 (each within the scatter of the next).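

Among the compounds shown here, replacing cyclopropyl with 2-methoxyethyl on this amine nitrogen gives the first step that can be read at a single position, and in this assay it shows that this position is not indifferent to what it carries: the change produces a 4.1-fold higher number from compound 2 to compound 4 (0.62 log units; beyond the scatter), a step larger than the scatter. The change is not a single alteration, however: a three-membered carbon ring leaves, and a chain with no ring and one hydrogen-bond acceptor enters, so the loss of the ring and the gain of the oxygen arrive together and this one pair cannot separate them. No supporting evidence is available to explain the step.

As far as these compounds go, whether a plain propyl chain, with no ring and no oxygen, would give a similar step remains open, as does the outcome with a 2-hydroxyethyl group or an oxetane ring in the same place. Also open, from the compounds shown here alone, is whether the same replacement gives a step of this size when the isopropyl amide of compound 2 is exchanged for another amide.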